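Changing the group on a carbonyl carbon

The source may hold more compounds than are shown below. What is called first, only, known or untested is meant among the compounds shown, and "the series" means these compounds.

Compound 1 `C=C1C(=O)O[C@H]2CC3=C[C@H](C/C(C)=C/[C@@H](OC(=O)C45CCC(C)(C(=O)O4)C5(C)C)[C@H]12)OC3=O`: 3400 nM
Compound 2 `C=C1C(=O)O[C@H]2CC3=C[C@H](C/C(C)=C/[C@@H](OC(=O)C4CC4)[C@H]12)OC3=O`: 3200 nM

Both compounds were tested in a functional assay on A549 cells (Homo sapiens) for cytotoxicity, read by MTT assay, with a stated time of 48 h; a lower number here means a stronger inhibitor, a higher number a weaker inhibitor. Compound 2 gives 3200 nM, and compound 1 gives 3400 nM; the step of a 1.1-fold lower number from compound 1 to compound 2 (0.03 log units; within the scatter) lies within the scatter, so the two numbers cannot be told apart.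

Compound 3 `C=C1C(=O)O[C@H]2CC3=C[C@H](C/C(C)=C/[C@@H](OC(=O)/C=C/c4cccs4)[C@H]12)OC3=O` differs from compound 2 in one place: 2-(thiophen-2-yl)ethenyl in place of cyclopropyl on a carbonyl carbon. For the measured compounds named here, the only measured step that bears on this position is a 1.1-fold lower number from compound 1 to compound 2 (0.03 log units; within the scatter), in which a much larger group on the same carbonyl carbon gave no change beyond the scatter. With just that one step as a guide, a step of similar size is expected here, in no particular direction, and compound 3 is expected to show a 1.1-fold lower number from compound 2 to compound 3 (0.03 log units; within the scatter). Compound 3 is therefore estimated at 3000 nM in this assay, with a range from 1200 nM to 7500 nM.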

Compound 3, half-maximal inhibitory concentration: 4300 nM
Compound 3: middle estimate off by 1.4-fold (0.16 log units), on the low side, within the range that was stated.
By their numbers in this assay, from the lowest: compounds 2, 1 and 3 (each within the scatter of the next).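

In this assay, putting 2-(thiophen-2-yl)ethenyl in place of cyclopropyl on a carbonyl carbon gives a 1.3-fold higher number from compound 2 to compound 3 (0.13 log units; within the scatter) and the comparison with the larger two-ring group reads a 1.3-fold higher number from compound 1 to compound 3 (0.10 log units; within the scatter). Both steps stay within the scatter, so this position has now taken a small carbon ring, a large two-ring group and a sulfur-containing aromatic ring on a double bond, and the three numbers cannot be told apart. The data give no measured reason for this lack of difference.

On these data alone, whether any group here can move the number beyond the scatter remains open, for example a chain ending in an amine or a carboxylic acid. Whether a simple longer carbon chain would behave like these three groups is also unknown.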